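The source may report more compounds than this note shows. Statements on the series, on what has been measured and on what is new or still open speak of the compounds shown alone.

Measured in a functional assay on MCF7 cells (Homo sapiens) for cytotoxicity; a lower number here means a stronger inhibitor, a higher number a weaker inhibitor:
- Compound 1 `C=C/C=C\[C@H](C)[C@H](OC(N)=O)[C@@H](C)[C@H](O)[C@@H](C)C/C(C)=C\[C@H](C)[C@@H](O)[C@@H](C)/C=C\CCc1ccc(Oc2ccccc2)cc1`: 10000 nM
- Compound 2 `C=C/C=C\[C@H](C)[C@H](OC(N)=O)[C@@H](C)[C@H](O)[C@@H](C)C/C(C)=C\[C@H](C)[C@@H](O)[C@@H](C)/C=C\CCc1cccc(Cl)c1`: 650 nM
- Compound 3 `C=C/C=C\[C@H](C)[C@H](OC(N)=O)[C@@H](C)[C@H](O)[C@@H](C)C/C(C)=C\[C@H](C)[C@@H](O)[C@@H](C)/C=C\CCc1cc(F)cc(F)c1`: 2000 nM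

These three compounds share a core and differ only in the aromatic group. Compound 3 sits in the middle of the three numbers, with compound 2 lower and compound 1 higher, and both gaps lie beyond the scatter.

The next compound to be tested is compound 4 `C=C/C=C\[C@H](C)[C@H](OC(N)=O)[C@@H](C)[C@H](O)[C@@H](C)C/C(C)=C\[C@H](C)[C@@H](O)[C@@H](C)/C=C\CCc1cccc(O)c1`, and its change from compound 3 is this: 3-hydroxyphenyl in place of 3,5-difluorophenyl on a saturated chain carbon, two bonds along the chain from a double-bonded chain carbon.

The most relevant measured comparison is a 3.1-fold higher number from compound 2 to compound 3 (0.49 log units; beyond the scatter). This modest step shows that exchanging one substituted phenyl group for another at this place can shift the number measurably. Going by the values given here, none of the measured compounds carries a 3-hydroxyphenyl group, however, so the data offer no direct guide to its effect. Compound 4 shares the 3-substituted pattern of compound 2, which gives 650 nM, so a slight move towards lower numbers in this assay seems more likely than a move towards higher ones, though this is only a weak expectation. The expected change is a 1.7-fold lower number from compound 3 to compound 4 (0.22 log units; within the scatter).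

For compound 4 the estimated value is 1200 nM, with an expected range from 300 nM to 5000 nM.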

Compound 4, half-maximal inhibitory concentration: 390 nM
Estimate against measurement, compound 4: 3.1-fold (0.49 log units) above, within the range that was stated.
By their numbers in this assay, from the lowest: compounds 4 and 2 (each within the scatter of the next); then compound 3; then compound 1.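

In this assay, going by these compounds alone, 3-hydroxyphenyl in place of 3,5-difluorophenyl on this saturated chain carbon gives a 5.1-fold lower number from compound 3 to compound 4 (0.71 log units; beyond the scatter), which shows that the aromatic group here can carry a hydrogen-bond donor without loss of activity against these cells, and that the earlier compounds, none of which has a donor on this group, did not cover the full reach of this position. Hydroxy in place of chloro on an aromatic carbon gives a 1.7-fold lower number from compound 2 to compound 4 (0.22 log units; within the scatter), so in this assay these two groups cannot be told apart, and a donor on the ring is therefore not shown to offer any gain over chloro. Nothing measured here explains why the hydroxy compound differs from the difluoro compound.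

A 3-methoxyphenyl group would test whether the hydroxy hydrogen matters at all, and a 3-aminophenyl group would test whether a different donor serves equally well. All the compounds shown also keep the same chain leading to the aromatic group, so the effect of a longer chain remains open.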